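The compounds below may be only part of what the source reports. "The series", "measured", "known", "first", "only" and "open" are said of these compounds alone.

Working notes on the series. For the measured compounds named here, in a functional assay on DU-145 cells (Homo sapiens) for inhibition, read by trypan blue exclusion, with a stated time of 96 h (on this read-out lower numbers stand for stronger inhibition of growth and higher numbers for weaker inhibition of growth), compound 1 (`O=C(/C(=C\c1ccc(OCc2ccccc2)cc1)SCc1ccc(Cl)cc1)c1ccc(Cl)cc1`) gives 1000 nM, the lower of the two numbers so far. Going by the values given here, the only measured comparison is compound 2 (`O=C(/C(=C\c1ccc(O)cc1)SCc1ccc(Cl)cc1)c1ccc(Cl)cc1`), which gives 10000 nM. Hydrogen in place of benzyl on an oxygen on an aromatic ring accounts for a 10-fold higher number from compound 1 to compound 2 (1.00 log units; beyond the scatter), a modest step beyond the scatter.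

Compound 3 (`O=C(/C(=C\c1ccc(OCc2ccccc2)cc1)SCc1ccc(Cl)cc1Cl)c1ccc(Cl)cc1`) is still to be measured in this assay. Its structural change from compound 1 is chloro in place of hydrogen on an aromatic carbon, which turns 4-chlorobenzyl into 2,4-dichlorobenzyl. That single measured step lies at a different place in the structure, so it gives no direct size for this change. Among the compounds with values here, no measured step alters the (4-chlorobenzyl)sulfanyl group. A small step is therefore expected, quite possibly within the scatter, with only a slight lean towards a lower number. The expected size is a 1.3-fold lower number from compound 1 to compound 3 (0.10 log units; within the scatter). Compound 3 is estimated at 800 nM, with an expected range from 250 nM to 3000 nM.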

Compound 3, concentration for 50% growth inhibition: 1000 nM
Compound 3: middle estimate off by 1.3-fold (0.10 log units), on the low side, and the stated range covers the measured number.
By their numbers in this assay, from the lowest: compounds 1 and 3 (each within the scatter of the next); then compound 2.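

In this assay, chloro in place of hydrogen on an aromatic carbon, ortho to a large group and meta to a chloro group, turns 4-chlorobenzyl into 2,4-dichlorobenzyl and gives no change at the digits printed from compound 1 to compound 3 (within the scatter). For the compounds shown here, this is the first reading on the (4-chlorobenzyl)sulfanyl group: one added chloro there leaves the printed number as it was, while a 10-fold higher number from compound 1 to compound 2 (1.00 log units; beyond the scatter) remains the only step beyond the scatter, and that step lies at the benzyl group on oxygen. No measurement at hand bears on the reason for this result.

On these data alone, a single chloro at one place says little about the wider reach of this group, so it remains open whether a methoxy group, an amine or a carboxylic acid at the same aromatic carbon would also leave the number within the scatter, or whether a longer chain in place of the 2,4-dichlorobenzyl group would do so. As far as these compounds go, it also remains open whether the same chloro step would read alike on the compound 2 background, which carries hydrogen in place of benzyl on the oxygen.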